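Sulfonate ester variation on a P2X7 antagonist scaffold

The source may hold more compounds than are shown below. What is called first, only, known or untested is meant among the compounds shown, and "the series" means these compounds.

Measured compounds:
- Compound 1 `O=C(Oc1ccc(-c2cncn2C2CCN(C(=O)c3ccc(Cl)c(C(F)(F)F)c3)CC2)cc1)c1cccc2cnccc12`: in an assay on HEK293 cells for antagonist activity at P2X purinoceptor 7 (Homo sapiens), read by fluorescence, with a stated time of 2 h (on this read-out lower numbers stand for stronger inhibition and higher numbers for weaker inhibition), compound 1 gives only the assay limit > 10000 nM.
- Compound 2 `CS(=O)(=O)Oc1ccc(-c2cncn2C2CCN(C(=O)c3ccc(Cl)c(C(F)(F)F)c3)CC2)cc1`: in this assay compound 2 gives 1570 nM.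
- Compound 3 `O=C(c1ccc(Cl)c(C(F)(F)F)c1)N1CCC(n2cncc2-c2ccc(OS(=O)(=O)c3cccc(Br)c3)cc2)CC1`: in this assay compound 3 gives 896 nM.

Of the two compounds with numbers, compound 3 and compound 2 sit within the usual scatter of each other, as the step of a 1.8-fold lower number from compound 2 to compound 3 (0.24 log units; within the scatter) shows. Compound 1 sits at the limit of > 10000 nM in this assay, at which 1 of the 3 values shown sits, and gives no number; the steps of an at least 6.3-fold lower number from compound 1 to compound 2 (0.80 log units; beyond the scatter) and an at least 11-fold lower number from compound 1 to compound 3 (1.04 log units; beyond the scatter) are both beyond the scatter, but they concern the replacement of the whole isoquinoline carbonyl by a sulfonate and do not touch the group varied here.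

Compound 4 `O=C(c1ccc(Cl)c(C(F)(F)F)c1)N1CCC(n2cncc2-c2ccc(OS(=O)(=O)c3cccc([N+](=O)[O-])c3)cc2)CC1` differs from compound 3 by nitro in place of bromo on an aromatic carbon. Within the data shown here, the only measured step on the sulfonyl substituent is the exchange of methyl for 3-bromophenyl, a 1.8-fold lower number from compound 2 to compound 3 (0.24 log units; within the scatter), which stayed within the scatter. A swap of one substituent for another on that phenyl ring is therefore expected to move the number by no more than the scatter in this assay, in no firm direction. The expected step is a 1.0-fold higher number from compound 3 to compound 4 (0.00 log units; within the scatter), and compound 4 is estimated at 900 nM, with a range from 300 nM to 3000 nM.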

Compound 4, half-maximal inhibitory concentration: 249 nM
The estimate for compound 4 lay 3.6-fold (0.56 log units) above the measured number; measured number below the stated range.
By their numbers in this assay, from the lowest: compound 4; then compounds 3 and 2 (each within the scatter of the next). At a limit, above all of these: compound 1.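

Unlike the exchange of methyl for 3-bromophenyl, which gave a 1.8-fold lower number from compound 2 to compound 3 (0.24 log units; within the scatter), the substituent on that phenyl ring now proves able to move the number in this assay: nitro in place of bromo gives a 3.6-fold lower number from compound 3 to compound 4 (0.56 log units; beyond the scatter), so the two groups are not interchangeable at this place on the ring. The aryl sulfonate also now separates from the methyl sulfonate, with 3-nitrophenyl in place of methyl on the sulfonyl sulfur giving a 6.3-fold lower number from compound 2 to compound 4 (0.80 log units; beyond the scatter), so the presence of a phenyl ring alone does not decide the outcome, as compound 3 shows by staying within the scatter of compound 2. The step of an at least 40-fold lower number from compound 1 to compound 4 (1.60 log units; beyond the scatter) starts from a limit and so gives only a bound on the distance, and nothing shown accounts for the difference between nitro and bromo.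

The compounds shown leave open how an amine, a carboxylic acid or a nitrile would compare with nitro and bromo on this phenyl ring. They also leave open whether nitro would give a similar step on a sulfonyl group carrying a naphthyl or pyridyl ring.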